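The source may report more compounds than this note shows. Statements on the series, on what has been measured and on what is new or still open speak of the compounds shown alone.

For the measured compounds named here, in a functional assay for inhibition, using microsomes, tested at 100 ug/mL (a lower number here means a stronger effect, a higher number a weaker effect of the compound at the concentration tested), compound 3 `CC1=C(C(=O)OC(C)(C)C)C(c2ccccc2)C=CN1c1ccccc1` gives -35.7%, the lowest of the three numbers measured so far. Compound 2 `CCOC(=O)C1=C(C)N(c2ccc(Cl)cc2)C=CC1c1ccccc1` gives -25.5%, and compound 1 `CCOC(=O)C1=C(C)N(c2ccccc2)C=CC1c1ccccc1` gives -19.9%, and both differences from compound 3 lie beyond the scatter. Compound 4 `CC1=C(C(=O)OC(C)(C)C)C(c2ccccc2)C=CN1c1ccc(Cl)cc1` differs from compound 3 by chloro in place of hydrogen on an aromatic carbon. The same change has been measured once before, from compound 1 to compound 2, where it gave a number 5.6 percentage points lower from compound 1 to compound 2 (within the scatter). The other known step, a number 15.8 percentage points lower from compound 1 to compound 3 (beyond the scatter), concerns tert-butyl in place of ethyl and does not bear on this change. Accordingly no step beyond the scatter is expected here, and the estimated step is a number 4.3 percentage points lower from compound 3 to compound 4 (within the scatter). Compound 4 is therefore expected to give -40%, with a likely range from -55% to -25%.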

Compound 4, a percentage reported as activity, at one concentration (the size of the read-out at that concentration, not a potency): -18.5%
For compound 4 the middle estimate is 21.5 percentage points below the measured one; measured number above the stated range.
By their numbers in this assay, from the lowest: compound 3; then compounds 2, 1 and 4 (each within the scatter of the next).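

In this assay the change from phenyl to 4-chlorophenyl has no single effect, as it now gives a number 17.2 percentage points higher from compound 3 to compound 4 (beyond the scatter) and the outcome depends on the core: the same change on two cores in this assay, a number 5.6 percentage points lower (within the scatter) from compound 1 to compound 2 and a number 17.2 percentage points higher (beyond the scatter) from compound 3 to compound 4, 22.8 percentage points apart, beyond the scatter of two such steps. The swap of ethyl for tert-butyl also differs once chloro is present, giving a number 7 percentage points higher from compound 2 to compound 4 (within the scatter) here: the same change on two cores in this assay, a number 15.8 percentage points lower (beyond the scatter) from compound 1 to compound 3 and a number 7 percentage points higher (within the scatter) from compound 2 to compound 4, 22.8 percentage points apart, beyond the scatter of two such steps. Across these four compounds the two changes therefore do not simply add up.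

The compounds shown leave open whether this dependence on the core is specific to chloro. A fluoro, methoxy or amine group at the same ring position could test that on both cores.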